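The source may report more compounds than this note shows. Statements on the series, on what has been measured and on what is new or still open speak of the compounds shown alone.

Measured compounds:
compound 1, `CC(C)COc1cccc(-c2ccc(C(=O)N(Cc3cccc(OCCCCCC(=O)O)c3)C(C)C)cc2)c1` — > 26000 nM
compound 2, `CCOc1cccc(-c2ccc(C(=O)N(Cc3cccc(OCCCCCC(=O)O)c3)C(C)C)cc2)c1` — > 20800 nM

In an ADME assay on HEK293 cells (Homo sapiens) for cytotoxicity, read by CellTiter-Glo and resazurin assay, with a stated time of 72 h (on this read-out higher numbers stand for an effect only at larger amounts of compound and lower numbers for an effect already at smaller amounts), compound 1 gives > 26000 nM, which is a limit of the assay and not a number. In this assay compound 2 gives > 20800 nM, likewise a limit and not a number. For the measured compounds named here, compound 2 therefore stands at a limit, and the only other value shown, that of compound 1, is also a limit; the one measured step, a step that the two limits leave unreadable from compound 1 to compound 2, cannot be read, since both of its ends sit at limits (the limit of > 20800 nM in this assay, at which 1 of the 2 values shown sits, (the limit of > 26000 nM in this assay, at which 1 of the 2 values shown sits)).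

Compound 3, `CC(C)N(Cc1cccc(OCCCCCC(=O)O)c1)C(=O)c1ccc(-c2cccc(S(C)(=O)=O)c2)cc1`, has not been measured. It differs from compound 2 by methylsulfonyl in place of ethoxy on an aromatic carbon. Going by the values given here, no measured step touches this kind of change, and the only step available is unreadable, so no direction and no size beyond the scatter can be expected from the data. The step from compound 2 to compound 3 in this assay is expected to be a step that the limit leaves unreadable from compound 2 to compound 3. Compound 3 is estimated at 25000 nM in this assay, within a range from 8000 nM to 60000 nM, with a good chance that only a limit is reported again.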

Compound 3, half-maximal effective concentration: > 26000 nM
Compound 3 was reported as a limit (the forecaster's own chance of this, stated with the estimate: 75%); middle value at least 1.0-fold (0.01 log units) away from the limit.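

In this assay, compound 1, compound 2 and compound 3 all stand at limits of the assay and not at numbers, and none of the steps among them can be read. The compounds shown leave open at what concentration each has its effect, and whether exchanging isobutoxy, ethoxy and methylsulfonyl changes it at all.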